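Notes on the amine substituent in the sulfonate series

The compounds below may be only part of what the source reports. "The series", "measured", "known", "first", "only" and "open" are said of these compounds alone.

Measured so far:
compound 1 `CCOC(=O)CNC(=O)NC1=CS(=O)(=O)O[C@@]12[C@@H](CO[Si](C)(C)C(C)(C)C)O[C@@H](n1cc(C)c(=O)n(C)c1=O)[C@@H]2O[Si](C)(C)C(C)(C)C`: 16000 nM
compound 2 `COC(=O)C(=O)CNC1=CS(=O)(=O)O[C@@]12[C@@H](CO[Si](C)(C)C(C)(C)C)O[C@@H](n1cc(C)c(=O)n(C)c1=O)[C@@H]2O[Si](C)(C)C(C)(C)C`: > 400000 nM

In a functional assay on HEL cells (Homo sapiens) for cytotoxicity, read by microscopy (a higher number here means that more compound is tolerated, a lower number that less compound is tolerated), compound 1 gives 16000 nM. For compound 2 the assay reports only a limit, > 400000 nM, and no number; compound 2 therefore stands at the better-tolerated end of the two values shown, as far as the limit tells. Among the measured compounds shown here, the one measured step is an at least 25-fold higher number from compound 1 to compound 2 (1.39 log units; beyond the scatter), ending at the limit of > 400000 nM in this assay, at which 1 of the 2 values shown sits.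

Compound 3 `Cc1cn([C@@H]2O[C@H](CO[Si](C)(C)C(C)(C)C)[C@@]3(OS(=O)(=O)C=C3NCCC(=O)OCc3ccccc3)[C@H]2O[Si](C)(C)C(C)(C)C)c(=O)n(C)c1=O` differs from compound 2 by (benzyloxycarbonyl)methyl in place of (methoxycarbonyl)carbonyl on a saturated chain carbon bound to an amine nitrogen. For the measured compounds named here, no measured step covers this change. The step from compound 1 to compound 2 bears on it only loosely: it shows that exchanging the group on the amine nitrogen can move this read-out by a large amount, and compound 3 brings back an ester-bearing chain, as in compound 1, while compound 2 carries the ketoester. A step downward beyond the scatter is therefore expected, though the limit on compound 2 leaves its size open; the expected step is an at least 4.0-fold lower number from compound 2 to compound 3 (0.60 log units; beyond the scatter). Compound 3 is expected to give about 100000 nM, within 16000 nM to 400000 nM.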

Compound 3, minimum cytotoxic concentration: >= 400000 nM
Compound 3 ended at the assay's limit; the forecaster's own chance of this, stated with the estimate: 35%; at least 4.0-fold (0.60 log units) between middle value and limit.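

Compound 3 in this assay gives a limit of the assay and not a number: the limit of >= 400000 nM in this assay, at which 1 of the 3 values shown sits.

Among the compounds shown here, with 2-(benzyloxycarbonyl)ethyl in place of ((ethoxycarbonyl)methyl)carbamoyl on an amine nitrogen, the read-out shows an at least 25-fold higher number from compound 1 to compound 3 (1.39 log units; beyond the scatter), so the large rise is no longer tied to ((methoxycarbonyl)carbonyl)methyl alone: two different groups at this position now reach the assay's limit, with compound 1 the only one of the three compounds giving a number. The step between compound 2 and compound 3 cannot be read, so the exchange of (methoxycarbonyl)carbonyl for (benzyloxycarbonyl)methyl on a saturated chain carbon bound to an amine nitrogen has no measurable size here.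

The compounds shown leave open whether the lower number of compound 1 belongs to the carbamoyl link or to its ((ethoxycarbonyl)methyl) end, and how far above the limit compound 2 and compound 3 would lie. A 2-carboxyethyl group, with a free carboxylic acid in place of the benzyl ester, or a plain carbamoyl group on the same amine nitrogen would bear on the first of these questions.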